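Swapping chloro for fluoro at a growth-inhibition limit

This account rests on a few compounds, and the source may have more. Where it says the series, first, only, none or still open, it means among the compounds named here.

- Compound 1 `CCc1nc(N)nc(N)c1-c1ccc(NCc2ccccc2OC)c([N+](=O)[O-])c1` gives 1500 nM
- Compound 2 `CCc1nc(N)nc(N)c1-c1ccc2[nH]c(-c3ccc(Cl)cc3)[n+]([O-])c2c1` gives > 50000 nM

In a functional assay on HT-29 cells (Homo sapiens) for inhibition (on this read-out higher numbers stand for weaker inhibition of growth and lower numbers for stronger inhibition of growth), compound 2 stands at > 50000 nM, which is a limit of the assay and not a number. Compound 3 `CCc1nc(N)nc(N)c1-c1ccc2[nH]c(-c3ccc(F)cc3)[n+]([O-])c2c1` has fluoro in place of chloro on an aromatic carbon, para to a large group (fluoro in place of chloro on an aromatic carbon). Among the measured compounds shown here, no measured pair shows what this swap does in this assay, so no step beyond the scatter is expected, and another limit is quite possible. The expected step is a number no higher from compound 2 to compound 3 (the limit leaves the size open). Compound 3 is estimated at about 50000 nM, with an expected range of 20000 nM to 100000 nM.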

Compound 3, concentration for 50% growth inhibition: 46000 nM
Beside the measured number, compound 3's estimate is 1.1-fold (0.04 log units) above it; the measured number falls inside the stated range.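

In this assay, compound 3 gives 46000 nM, so with fluoro this position yields a real number. Compound 2 stands at > 50000 nM, which is a limit of the assay and not a number, so the swap can only be bounded from one side: the limit of > 50000 nM in this assay, at which 1 of the 3 values shown sits.

Going from 4-chlorophenyl to 4-fluorophenyl therefore gives an at least 1.0-fold lower number from compound 2 to compound 3 (0.03 log units; that floor lies within the scatter), and nothing shows a real gain. Going by these compounds, the true size of this step stays open, as does the effect of an amine or a nitrile at this place.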